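Isopropyl to propyl on compound 1

This account rests on a few compounds, and the source may have more. Where it says the series, first, only, none or still open, it means among the compounds named here.

Measured so far in an ADME assay on the whole organism for inhibition, with Oryza sativa as the target, with a stated time of 4 days; a lower number here means a stronger inhibitor, a higher number a weaker inhibitor:
- compound 1 `CCN(c1nc(Cl)nc(N[C@H](C)c2ccccc2)n1)C(C)C`: 3550 nM
- compound 2 `C[C@H](Nc1nc(Cl)nc(NC(C)(C)C)n1)c1ccccc1`: 3310 nM

Compound 1 at 3550 nM stands within the scatter of compound 2 at 3310 nM, so the two values cannot be ordered.

Compound 3 `CCCN(CC)c1nc(Cl)nc(N[C@H](C)c2ccccc2)n1` has not yet been measured. It differs from compound 1 by a single change: propyl in place of isopropyl on a nitrogen on an aromatic ring. In words, this is propyl in place of isopropyl on a nitrogen on an aromatic ring. Among the measured compounds shown here, no measured pair sizes such a change, so the expectation rests on compound 1 at 3550 nM as the starting point. No shift beyond the scatter is expected in this assay, in either direction, though the uncertainty is wide. The estimated step is a 1.0-fold lower number from compound 1 to compound 3 (0.02 log units; within the scatter). For compound 3 the expected value is 3400 nM, with an estimated range of 1500 nM to 8000 nM.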

Compound 3, half-maximal inhibitory concentration: 24500 nM
Compound 3: the middle estimate sits 7.2-fold (0.86 log units) below what was measured, and the stated range ends below it.
By their numbers in this assay, from the lowest: compounds 2 and 1 (each within the scatter of the next); then compound 3.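

In this assay the step from isopropyl to propyl on a nitrogen on an aromatic ring is a 6.9-fold higher number from compound 1 to compound 3 (0.84 log units; beyond the scatter) and marks a weaker inhibitor. Among the compounds shown here, this is the first sized change at this position, and it shows that the position responds to the arrangement of the chain: the two groups have the same count of 3 heavy atoms, with no ring, hydrogen-bond donors, hydrogen-bond acceptors or net charge on either side. No measured evidence accounts for the size of this step.

As far as these compounds go, whether a methyl, a cyclopropyl or a longer chain on this nitrogen would read closer to isopropyl or to propyl remains open. Also open, from the compounds shown here alone, is whether the same swap would give a similar step on another member of the series.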